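The compounds below may be only part of what the source reports. "The series", "measured", "known", "first", "only" and "open" are said of these compounds alone.

Three compounds from one series share a core in which a ring system carrying a nitrogen and an oxygen is attached to a flat, oxygen-containing bicyclic core that bears a phenyl group. They were tested in a functional assay on MCF7 cells (Homo sapiens) for inhibition, read by MTT assay, with a stated time of 48 h, tested at 7.5 ug/mL; a lower number here means less inhibition of growth, a higher number more inhibition of growth at the concentration tested. Compound 1 `O=c1cc(-c2ccccc2)oc2cc(N3COc4c(cccc4[N+](=O)[O-])C3)ccc12` carries a nitro group on the attached ring system and is reported in this assay as "not active" (no number reported), without a number. Compound 2 `O=c1cc(-c2ccccc2)oc2ccc(N3COc4c(Br)cc(Br)cc4C3)cc12` carries two bromine atoms and gives in this assay a value of 6.54%. Compound 3 `Cc1cccc2c1OCN(c1ccc3oc(-c4ccccc4)cc(=O)c3c1)C2` carries a methyl group and gives in this assay a value of 30.4%, the higher of the two numbers; the gap to compound 2 lies beyond the usual scatter.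

Compound 4 `O=c1cc(-c2ccccc2)oc2ccc(N3COc4ccccc4C3)cc12` has not yet been measured. It differs from compound 3 in one place: hydrogen in place of methyl on an aromatic carbon. Among the compounds with values here, no measured pair in this set shows what such a change does, so the step from compound 3 to compound 4 is expected on the spread of the known values alone. Since the substituted compounds 1 and 2 gave little or no inhibition and only compound 3 gave more, the unsubstituted compound 4 is expected to sit somewhat below compound 3, by a step of a number 12.4 percentage points lower from compound 3 to compound 4 (beyond the scatter). Compound 4 is thus estimated to give about 18% in this assay, with a range from 5% to 35%.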

Compound 4, percent growth inhibition at one concentration: 8.7%
For compound 4 the middle estimate is 9.3 percentage points above the measured one, within the range that was stated.
By their numbers in this assay, from the lowest: compounds 2 and 4 (each within the scatter of the next); then compound 3.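

Within the data shown here, the step of a number 21.7 percentage points lower from compound 3 to compound 4 (beyond the scatter) in this assay is the first direct reading of this position, since hydrogen replaces methyl on an aromatic carbon of the six-membered aromatic ring and the rest of the structure stays the same. Among these compounds, earlier comparisons among the compounds could only set values side by side, whereas this pair shows that one carbon atom at this place is enough to move the read-out beyond the usual scatter, so the higher growth inhibition of compound 3 goes with its methyl group and is not carried by the rest of its structure alone. Nothing available here explains why this small change has an effect of this size.

This single pair leaves open how other groups would behave at the same aromatic carbon, such as an ethyl chain, a methoxy group, an amine or a carboxylic acid, and whether a larger group would raise the inhibition further or lower it. It also leaves open whether the gap between compound 3 and compound 4 would persist at other concentrations, as each compound is read at a single concentration.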